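The source may hold more compounds than are shown below. What is called first, only, known or untested is meant among the compounds shown, and "the series" means these compounds.

Among the measured compounds shown here, in a functional assay on L6 cells (Rattus norvegicus) for inhibition (a lower number here means a stronger inhibitor, a higher number a weaker inhibitor), compound 3 `CC(C)c1c(C(=O)NCc2ccccc2)nn(-c2ccc(F)cc2)c1OC[C@@H](O)C[C@@H](O)CC(=O)O` takes the middle place at 880 nM with compound 1 `CC(C)c1c(C(=O)N2CCC[C@H](c3ccccc3)C2)nn(-c2ccc(F)cc2)c1CC[C@@H](O)C[C@@H](O)CC(=O)O` lower at 310 nM and compound 2 `CC(C)c1c(C(=O)N(C)Cc2cccc(F)c2)nn(-c2ccc(F)cc2)c1CC[C@@H](O)C[C@@H](O)CC(=O)O` higher at 1900 nM among the numbers so far. Compound 4 `CC(C)c1c(C(=O)N(C)Cc2ccccc2)nn(-c2ccc(F)cc2)c1OC[C@@H](O)C[C@@H](O)CC(=O)O` departs from compound 3 by one change, methyl in place of hydrogen on an amide-type nitrogen with methyl in place of hydrogen on an amide-type nitrogen. For the measured compounds named here, no measured step makes this exact change. The closest evidence is a 6.1-fold higher number from compound 1 to compound 2 (0.79 log units; beyond the scatter) and that step exchanges one amide lacking the amide hydrogen for another, so it bears only loosely. Compound 1 and compound 2 both lack the amide hydrogen, yet their values fall on either side of the value of compound 3, so the data suggest no direction. Compound 2 also differs from compound 3 elsewhere in the structure. A step smaller than the measured one is expected in this assay and most likely none beyond the scatter. As far as these compounds go, the expected step is a 1.1-fold higher number from compound 3 to compound 4 (0.06 log units; within the scatter) and its direction remains open. Compound 4 is estimated at 1000 nM with an expected range of 350 nM to 2800 nM in this series.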

Compound 4, half-maximal inhibitory concentration: 6720 nM
Estimate against measurement, compound 4: 6.7-fold (0.83 log units) below; the measured number lies above the stated range.
By their numbers in this assay, from the lowest: compound 1; then compound 3; then compound 2; then compound 4.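

In this assay, putting methyl in place of hydrogen on the amide-type nitrogen of the benzylcarbamoyl group gives a 7.6-fold higher number from compound 3 to compound 4 (0.88 log units; beyond the scatter) and so moves toward a weaker inhibitor. Compound 1 and compound 2 both lack the amide hydrogen, so their step could not show the direction of this change; the pair of compound 3 and compound 4 isolates it on one core and shows that the single added carbon is enough to move the value beyond the scatter. Nothing available explains this loss.

The compounds shown do not tell whether the same change has a similar effect on the core of compound 1. They also leave open whether an ethyl or a 2-hydroxyethyl group on this nitrogen would behave as methyl does.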